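Swapping the Amine Substituent on a Shared Core

The source may hold more compounds than are shown below. What is called first, only, known or untested is meant among the compounds shown, and "the series" means these compounds.

Compound 1, `O=C1C(N2CCCCC2)=CC(=O)c2c1nc1n2[C@H]2OC[C@@H](O)[C@H]2OC1`: > 16000 nM
Compound 2, `O=C1C=C(NCc2ccccc2)C(=O)c2c1nc1n2[C@H]2OC[C@@H](O)[C@H]2OC1`: > 8000 nM

Both numbers come from a functional assay on HeLa cells (Homo sapiens) for inhibition, read by sulforhodamine B assay; a lower number here means a stronger inhibitor, a higher number a weaker inhibitor. For compound 1 the reading > 16000 nM is a limit of the assay rather than a number. For compound 2 the reading > 8000 nM is likewise a limit, so compound 2 stands at the limit of > 8000 nM in this assay, at which 1 of the 2 values shown sits, and no true value is known for it. Compound 3, `CCOc1ccccc1NC1=CC(=O)c2nc3n(c2C1=O)[C@H]1OC[C@@H](O)[C@H]1OC3`, keeps the core of compound 2 and differs only on the amine nitrogen: 2-ethoxyphenyl in place of benzyl on an amine nitrogen. Going by the values given here, no measured step between two compounds is available to weigh this change, so the step that the limit leaves unreadable from compound 2 to compound 3 is expected to amount to nothing beyond the scatter, in either direction. Compound 3 is therefore estimated to give about 12000 nM in this assay, with a range from 2500 nM to 50000 nM, and most likely again only a limit.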

Compound 3, half-maximal inhibitory concentration: 6040 nM
Compound 3: the middle estimate sits 2.0-fold (0.30 log units) above what was measured; low and high end bracket the measured number.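

In this assay, going by these compounds alone, compound 3 gives 6040 nM as a number rather than a limit, the only such reading among the three compounds, so this amine nitrogen can carry an aryl group, here 2-ethoxyphenyl, and still give a value within the range of the assay. Putting 2-ethoxyphenyl in place of benzyl gives an at least 1.3-fold lower number from compound 2 to compound 3 (0.12 log units; that floor lies within the scatter) and so shows no gain beyond the scatter on that floor alone. The full size of the step cannot be read because compound 2 is held only by a limit: the limit of > 8000 nM in this assay, at which 1 of the 3 values shown sits.

The compounds shown leave open what a plain phenyl, a 2-methoxyphenyl or a 4-ethoxyphenyl on the same amine nitrogen would give, and so whether the ethoxy group matters at all. Also open, going by these compounds, is how a 2-aminoethyl chain there would read in this assay.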